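Chloroacetyl Replaces Pivaloyl in a Sulfonate Ester Series

The source may report more compounds than this note shows. Statements on the series, on what has been measured and on what is new or still open speak of the compounds shown alone.

Measured so far:
compound 1 `CC(=O)Nc1ccc(S(=O)(=O)Oc2ccccc2C(C)C)cc1` gives 16000 nM
compound 2 `CCCCCC(=O)Nc1ccc(S(=O)(=O)Oc2ccccc2C(C)C)cc1` gives 5300 nM
compound 3 `CC(C)c1ccccc1OS(=O)(=O)c1ccc(NC(=O)C(C)(C)C)cc1` gives 6500 nM

These three compounds share one core and differ only in the acyl group on the amide nitrogen. In a functional assay on MCF7 cells (Homo sapiens) for antiproliferative activity, read by sulforhodamine B assay, with a stated time of 48 h (on this read-out lower numbers stand for stronger inhibition and higher numbers for weaker inhibition), compound 3 stands second highest of the three numbers; its nearest neighbour is compound 2, and the gap a 1.2-fold higher number from compound 2 to compound 3 (0.09 log units; within the scatter) lies within the scatter, so the two cannot be ordered. Compound 1, with the smallest acyl group, sits furthest away: a 2.5-fold lower number from compound 1 to compound 3 (0.39 log units; beyond the scatter), and likewise a 3.0-fold lower number from compound 1 to compound 2 (0.48 log units; beyond the scatter). Both measured steps that start from compound 1 point the same way: enlarging the group on the carbonyl carbon gave a lower number, of modest size.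

Compound 4 `CC(C)c1ccccc1OS(=O)(=O)c1ccc(NC(=O)CCl)cc1` is not yet measured. The change from compound 3 is chloromethyl in place of tert-butyl on a carbonyl carbon. The acyl group thus becomes smaller again, closer in size to that of compound 1 than to the tert-butyl of compound 3. The steps from compound 1 suggest that a smaller acyl group goes with a higher number, so a modest rise is expected: compound 4 is estimated at 10000 nM, with a range from 4000 nM to 25000 nM. Going by the values given here, the expected step of a 1.5-fold higher number from compound 3 to compound 4 (0.19 log units; within the scatter) would be modest, since no measured pair tells how a chlorine on that chain behaves.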

Compound 4, half-maximal inhibitory concentration: 2900 nM
Beside the measured number, compound 4's estimate is 3.4-fold (0.54 log units) above it; measured number outside the range, below it.
By their numbers in this assay, from the lowest: compounds 4, 2 and 3 (each within the scatter of the next, the first and the last beyond it); then compound 1.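

Size alone no longer orders the groups on this carbonyl carbon: the earlier steps linked larger groups to lower numbers, yet in this assay chloromethyl, with 2 heavy atoms against 4 in tert-butyl, gives a 2.2-fold lower number from compound 3 to compound 4 (0.35 log units; beyond the scatter) and so goes against that pattern. A single chloro in place of hydrogen on the chain carbon gives a 5.5-fold lower number from compound 1 to compound 4 (0.74 log units; beyond the scatter), the largest step among these compounds, while a 1.8-fold lower number from compound 2 to compound 4 (0.26 log units; within the scatter) leaves compound 2 and compound 4 unordered. Nothing shown offers a measured explanation for this result.

Going by these compounds, whether chlorine specifically matters remains open, as does whether any small group carrying a different atom on that chain carbon would behave alike. A bromomethyl, hydroxymethyl or aminomethyl group on the same carbonyl carbon would address that question.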